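The source may hold more compounds than are shown below. What is called first, only, known or untested is meant among the compounds shown, and "the series" means these compounds.

Compound 1 `COc1ccccc1N1CCN(CCCCC(=O)NCc2ccccc2-c2c(OC)cccc2OC)CC1`: 32.4 nM
Compound 2 `COc1ccccc1N1CCN(CCCCC(=O)NCc2ccccc2-c2ccccc2F)CC1`: 36.5 nM

In an assay on CHO-K1 cells for displacement of a labelled ligand from 5-hydroxytryptamine receptor 7 (Homo sapiens), read by scintillation counting (on this read-out higher numbers stand for weaker inhibition and lower numbers for stronger inhibition), compound 1 gives 32.4 nM and compound 2 gives 36.5 nM; the two lie within the scatter of each other, so neither stands apart. Compound 3 `COc1ccccc1N1CCN(CCCCC(=O)NCc2ccccc2-c2ccccc2)CC1` differs from compound 2 by hydrogen in place of fluoro on an aromatic carbon. Within the data shown here, the only measured step that bears on this place is a 1.1-fold higher number from compound 1 to compound 2 (0.05 log units; within the scatter), a larger swap at the same aromatic carbon that left this assay unchanged. A smaller change there is therefore expected to give a 1.1-fold higher number from compound 2 to compound 3 (0.04 log units; within the scatter), nothing beyond the scatter. Compound 3 is estimated at 40 nM, ranging from 15 nM to 100 nM.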

Compound 3, inhibition constant: 37.9 nM
Estimate against measurement, compound 3: 1.1-fold (0.02 log units) above; the measured number falls inside the stated range.
By their numbers in this assay, from the lowest: compounds 1, 2 and 3 (each within the scatter of the next).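

In this assay, hydrogen in place of fluoro (a 1.0-fold higher number from compound 2 to compound 3 (0.02 log units; within the scatter)) and phenyl in place of 2,6-dimethoxyphenyl (a 1.2-fold higher number from compound 1 to compound 3 (0.07 log units; within the scatter)) both leave the number within the scatter. Compound 3 thus adds the unsubstituted phenyl to the series, showing that among these three compounds neither the fluoro nor the two methoxy groups is needed to keep the number at this level. No evidence is available here to explain this flat result. Going by these compounds, whether an amine or a carboxylic acid on this ring would also leave the number unchanged remains open.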